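Methoxyphenyl in place of dimethylphenyl on the ring nitrogen

The source may report more compounds than this note shows. Statements on the series, on what has been measured and on what is new or still open speak of the compounds shown alone.

Compound 1 `Cc1ccc(N2CCN(CC(=O)N(c3ccccc3)c3ccccc3)CC2)cc1` gives 31.2 mg/kg in a functional assay on the whole organism (strain Swiss albino) for inhibition, with Mus musculus as the target, with stated times of 30 min, 10 min and 20 min; on this read-out higher numbers stand for an effect only at larger amounts of compound and lower numbers for an effect already at smaller amounts.
Compound 2 `Cc1cccc(N2CCN(CC(=O)N(c3ccccc3)c3ccccc3)CC2)c1C` gives > 30 mg/kg in this assay; this is a limit of the assay, not a number.
Compound 3 `O=C(CN1CCN(c2cccc(C(F)(F)F)c2)CC1)N(c1ccccc1)c1ccccc1` gives 30 mg/kg in this assay.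

Compound 2 stands only as a limit on the numbers shown, so its position relative to the other two cannot be fixed. The step that the limit leaves unreadable from compound 1 to compound 2 is therefore unreadable, and so is a number no higher from compound 2 to compound 3 (the limit leaves the size open); both rest on (the limit of > 30 mg/kg in this assay, at which 1 of the 3 values shown sits). Going by the values given here, the one readable comparison, a 1.0-fold lower number from compound 1 to compound 3 (0.02 log units; within the scatter), shows that changing the group on the ring nitrogen from one substituted phenyl to another left the dose unchanged within the scatter.

Compound 4 `COc1ccccc1N1CCN(CC(=O)N(c2ccccc2)c2ccccc2)CC1` differs from compound 2 by 2-methoxyphenyl in place of 2,3-dimethylphenyl on an amine nitrogen in a ring. The measured steps give no sign that this kind of change moves the dose, and the three known compounds all sit at or near the limit of the assay. A step of no clear size is therefore expected from compound 2 to compound 4, written as a number no higher from compound 2 to compound 4 (the limit leaves the size open), with a real chance that the assay again gives only a limit. Compound 4 is estimated at 30 mg/kg, within 15 mg/kg to 60 mg/kg.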

Compound 4, dose for half-maximal effect: 12.7 mg/kg
The estimate for compound 4 lay 2.4-fold (0.37 log units) above the measured number, and the stated range ends above it.
By their numbers in this assay, from the lowest: compound 4; then compounds 3 and 1 (each within the scatter of the next).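

Among the groups on the ring nitrogen, 2-methoxyphenyl is the first to stand apart in this assay, giving a 2.4-fold lower number from compound 3 to compound 4 (0.37 log units; beyond the scatter) and a 2.5-fold lower number from compound 1 to compound 4 (0.39 log units; beyond the scatter), whereas the one comparison readable before had shown no change beyond the scatter. Against compound 2 the change gives an at least 2.3-fold lower number from compound 2 to compound 4 (0.37 log units; beyond the scatter), and that size is only a lower bound on the step, which rests on a limit: the limit of > 30 mg/kg in this assay, at which 1 of the 4 values shown sits. The swap from 2,3-dimethylphenyl to 2-methoxyphenyl keeps the count of 8 heavy atoms and adds one hydrogen-bond acceptor, but nothing shown ties the lower number to that acceptor or to any other feature of the group.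

The steps from compound 1 to compound 2 and from compound 2 to compound 3 still cannot be read. Going by these compounds, it also stays open whether the lower number belongs to the methoxy group as such or to 2-methoxyphenyl in particular, which 4-methoxyphenyl, 2-ethoxyphenyl or 2-hydroxyphenyl on the same ring nitrogen could help to settle.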